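A few compounds are considered here, and "the series" means these few. Any claim that something is new, unique, unknown or untested is made for them only; others in the source may bear on it.

Compound 3, with the structure `CCOC(=O)C1=C(C)NC(C)=C(C(=O)OCC2CCCCC2)C1c1[nH]cnc1Cl`, was measured in an assay on isolated protein for inhibition of Voltage-dependent L-type calcium channel subunit alpha-1C (Cavia porcellus) (a higher number here means a weaker inhibitor, a lower number a stronger inhibitor), and gave 513 nM. Among the three compounds measured so far, that number sits second highest: compound 1, `CCOC(=O)C1=C(C)NC(C)=C(C(=O)OC)C1c1[nH]cnc1Cl`, gives 661 nM in this assay, and the difference between them is a 1.3-fold lower number from compound 1 to compound 3 (0.11 log units; within the scatter), whereas compound 2, `COC(=O)C1=C(C)NC(C)=C(C(=O)OCc2ccccc2)C1c1[nH]cnc1Cl`, gives 93.3 nM, well apart from compound 3.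

Compound 4, `CCOC(=O)C1=C(C)NC(C)=C(C(=O)OCc2ccccc2)C1c1[nH]cnc1Cl`, has not yet been measured. It differs from compound 3 in one place: phenyl in place of cyclohexyl on a saturated chain carbon bound to an oxygen next to a carbonyl group. Two earlier steps inform the expectation. Adding a cyclohexyl to the ester chain changed little, as a 1.3-fold lower number from compound 1 to compound 3 (0.11 log units; within the scatter) shows. Putting a phenyl on the same chain carbon instead of a methyl, however, gave a 7.1-fold lower number from compound 1 to compound 2 (0.85 log units; beyond the scatter), a clear gain that lies beyond the scatter. Compound 4 carries the same benzyl ester as compound 2, with the ester on the other side matching that of compound 3, so a similar gain is anticipated when the cyclohexyl becomes a phenyl.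

Compound 4 is therefore expected to show a step of a 4.7-fold lower number from compound 3 to compound 4 (0.67 log units; beyond the scatter) in this assay. The estimated value for compound 4 is 110 nM, with a likely range from 40 nM to 300 nM.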

Compound 4, half-maximal inhibitory concentration: 91.2 nM
Beside the measured number, compound 4's estimate is 1.2-fold (0.08 log units) above it; the range from low to high includes it.
By their numbers in this assay, from the lowest: compounds 4 and 2 (each within the scatter of the next); then compounds 3 and 1 (each within the scatter of the next).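

Both rings hold the same count of carbon atoms, and a non-aromatic ring gives way to an aromatic one. In this assay that swap gives a 5.6-fold lower number from compound 3 to compound 4 (0.75 log units; beyond the scatter) with the rest of the molecule untouched. At this chain carbon, then, the identity of the ring matters, which compound 3 and compound 1 alone could not show, since cyclohexyl there had left the number within the scatter. The benzyl ester also holds its effect whatever stands on the other ester: methyl in place of hydrogen there gives a 1.0-fold lower number from compound 2 to compound 4 (0.01 log units; within the scatter) and so no real change, while a 7.2-fold lower number from compound 1 to compound 4 (0.86 log units; beyond the scatter) shows the gain from phenyl on the ester chain with that other ester kept the same.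

No measurement shown here explains why phenyl and cyclohexyl differ at this position.
From the compounds shown here alone, it remains open whether a pyridine ring in place of the phenyl, a chlorine or methoxy group on the phenyl, or a longer chain between the ester oxygen and the phenyl would keep the number as low as that of compound 4.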